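The source may report more compounds than this note shows. Statements on the series, on what has been measured and on what is new or still open speak of the compounds shown alone.

Of the compounds shown here, three built on one shared core have been tested in a functional assay on L1210 cells (Mus musculus) for inhibition, read by MTT assay; a lower number here means a stronger inhibitor, a higher number a weaker inhibitor. Compound 1 `N#CC1CN1C(=O)Nc1ccc(Cl)cc1Cl` gives 207000 nM in this assay. Compound 2 `N#CC1CN1C(=O)Nc1ccc(S(N)(=O)=O)cc1` gives in this assay only a limit of the assay, > 38000 nM. For the measured compounds named here, compound 3 `CNC(=O)N1CC1C#N`, which carries a methylamino group, gives 8700 nM in this assay; that is the lower of the two numbers known, and compound 1 sits well beyond the usual scatter above it. Compound 4 `CCNC(=O)N1CC1C#N` has not yet been measured. It differs from compound 3 in one place: methyl in place of hydrogen on a saturated chain carbon bound to an amide-type nitrogen. In this assay a step that stays within the usual scatter is expected, a 1.2-fold lower number from compound 3 to compound 4 (0.09 log units; within the scatter). Compound 4 is therefore estimated at 7000 nM, with a likely range from 2500 nM to 25000 nM.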

Compound 4, half-maximal inhibitory concentration: 14000 nM
Compound 4: middle estimate off by 2.0-fold (0.30 log units), on the low side, within the range that was stated.
By their numbers in this assay, from the lowest: compounds 3 and 4 (each within the scatter of the next); then compound 1.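

Going from methylamino to ethylamino gives the first step read at this position in this assay: a 1.6-fold higher number from compound 3 to compound 4 (0.21 log units; within the scatter) and so leaves compound 3 and compound 4 not distinguishable from each other. At this place on the chain, the added methyl is therefore tolerated without a measurable loss of activity. No measured property shown here bears on this step. Still open, going by these compounds, is whether a longer chain such as butyl would also be tolerated here, and whether a chain ending in a carboxylic acid or an amine would give a similar number.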